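Benzyl for phenyl on a nitrogen: an expected small step

This account rests on a few compounds, and the source may have more. Where it says the series, first, only, none or still open, it means among the compounds named here.

Within the data shown here, compound 2 `Nc1ccccc1NC(=O)/C=C/c1ccc(Cn2cnc3c(Nc4ccccc4)nc(Cl)nc32)cc1` gives 30.9% in a functional assay on HCT-116 cells (Homo sapiens) for antiproliferative activity, read by CCK-8 assay, with a stated time of 72 h, tested at 8 uM (on this read-out higher numbers stand for a stronger effect at the one concentration tested and lower numbers for a weaker effect), the higher of the two numbers measured so far. Among the measured compounds shown here, its only neighbour, compound 1 `Nc1ccccc1NC(=O)/C=C/c1ccc(Cn2cnc3c(NC4CCCCC4)nc(Cl)nc32)cc1`, gives 18.7% in this assay, and the step of a number 12.2 percentage points higher from compound 1 to compound 2 (beyond the scatter) is the sole measured step, beyond the scatter. Compound 3 `Nc1ccccc1NC(=O)/C=C/c1ccc(Cn2cnc3c(NCc4ccccc4)nc(Cl)nc32)cc1` has not yet been measured; it differs from compound 2 by benzyl in place of phenyl on a nitrogen on an aromatic ring. For the measured compounds named here, the change sits on a nitrogen on an aromatic ring, the same place that the one measured step altered, so that modest step is the only guide. A benzyl group is neither the cyclohexyl of compound 1 nor the phenyl of compound 2, and nothing measured tells whether leaving phenyl repeats the earlier gain or gives part of it back. The account therefore expects for compound 3 a step of a number 4.9 percentage points lower from compound 2 to compound 3 (within the scatter) that stays within the scatter, if anything slightly downward. The estimated value for compound 3 in this assay is 26%, with a range from 10% to 44%.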

Compound 3, a percentage reported as inhibition, at one concentration (the size of the read-out at that concentration, not a potency): 17.4%
Beside the measured number, compound 3's estimate is 8.6 percentage points above it; the range from low to high includes it.
By their numbers in this assay, from the lowest: compounds 3 and 1 (each within the scatter of the next); then compound 2.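

In this assay, moving from anilino to benzylamino on this nitrogen gives a number 13.5 percentage points lower from compound 2 to compound 3 (beyond the scatter), so the gain seen with phenyl does not carry over to benzyl, although both groups hold the same six-membered aromatic ring of carbon only. Benzyl and cyclohexyl do not separate, with a number 1.3 percentage points lower from compound 1 to compound 3 (within the scatter), which leaves phenyl as the only one of the three groups whose steps to both others lie beyond the scatter. Nothing available accounts for this difference between phenyl and benzyl.

On these data alone, whether a phenyl ring carrying a methoxy group, or phenethyl with its longer chain, would keep the number of compound 2 remains open, as does the effect of a small group such as methyl on this nitrogen. All three compounds share the rest of the structure, so whether this order holds on a changed core cannot be said.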